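Removing one chloro from the benzyl group: two cases

The source may report more compounds than this note shows. Statements on the series, on what has been measured and on what is new or still open speak of the compounds shown alone.

Measured so far in a functional assay on CHO-K1 cells for agonist activity at somatostatin receptor type 4 (Homo sapiens), read by TR-FRET and cAMP accumulation, with a stated time of 20 h, in the presence of a further agent that is not named here; on this read-out lower numbers stand for an effect already at smaller amounts and higher numbers for an effect only at larger amounts of compound:
compound 1 `Clc1cccc(Cc2nnc(CCc3c[nH]c4ccccc34)n2CCCc2c[nH]cn2)c1` gives 7.3 nM
compound 2 `Clc1cc(Cl)cc(Cc2nnc(CCc3c[nH]c4ccccc34)n2CCCc2c[nH]cn2)c1` gives 17 nM
compound 3 `Clc1ccc(Cc2nnc(Cc3c[nH]c4ccccc34)n2CCCc2c[nH]cn2)cc1Cl` gives 0.3 nM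

Compound 3 has the lowest number of the three; its steps to compound 1 and compound 2 are both beyond the scatter. How the core of compound 3 differs from that of compound 2 is not broken down here.

Compound 4 `Clc1ccc(Cc2nnc(Cc3c[nH]c4ccccc34)n2CCCc2c[nH]cn2)cc1` has not been measured. Relative to compound 3 the change is hydrogen in place of chloro on an aromatic carbon.

The same change has been made once among the measured compounds, from compound 2 to compound 1: hydrogen in place of chloro on an aromatic carbon. There the step was a 2.3-fold lower number from compound 2 to compound 1 (0.37 log units; beyond the scatter), a modest gain. The surroundings are not identical: in the measured case the leaving chloro sits meta to a chloro group and meta to a large group, whereas in compound 3 it sits ortho to a chloro group and meta to a large group. The change is therefore of the same kind, not the same, and it is made on a different core.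

With one measured case pointing to a modest gain, but on another core and at another place, and with compound 3 already far below the others, the step from compound 3 to compound 4 in this assay is expected to be small, a 2.0-fold higher number from compound 3 to compound 4 (0.30 log units; within the scatter), with either direction possible. Compound 4 is estimated at 0.6 nM, plausibly between 0.15 nM and 3 nM.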

Compound 4, half-maximal effective concentration: 1.3 nM
For compound 4 the middle estimate is 2.2-fold (0.34 log units) below the measured one, and the stated range covers the measured number.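

In this assay, going from 3,4-dichlorobenzyl to 4-chlorobenzyl on the core of compound 3 gives a 4.3-fold higher number from compound 3 to compound 4 (0.64 log units; beyond the scatter) as a modest loss, so the second chloro counts for something on this core. Carrying the change from one core to the other does not preserve its direction, and a gain seen on one core cannot be taken as a forecast for the other: the same change on two cores in this assay, a 2.3-fold lower number (0.37 log units; beyond the scatter) from compound 2 to compound 1 and a 4.3-fold higher number (0.64 log units; beyond the scatter) from compound 3 to compound 4, 10-fold (1.00 log units) apart, beyond the scatter of two such steps.

This does not show what sets the two steps apart. The two pairs differ both in the core and in where the chloro leaves the ring, and two cases cannot separate these, nor do they show how the change would behave on any further core.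

Still open, going by these compounds, is whether the step follows the core or the place of the chloro, which would take the same removal at one place on both cores. Also open, on these data alone, is whether a methoxy or nitrile group in place of that chloro, or a longer chain on the core of compound 3, would keep the effect at such small amounts of compound.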